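The compounds below may be only part of what the source reports. "The series", "measured", "known", "first", "only" and "open" are said of these compounds alone.

- Compound 1 `CC1CCN(C2CCN(S(=O)(=O)c3ccc(C#N)cc3)CC2)CC1`: > 5000 nM
- Compound 2 `CC1CCN(C2CCN(S(=O)(=O)c3nccn3C)CC2)CC1`: > 10000 nM
- Compound 3 `CCc1ccc(S(=O)(=O)N2CCC(N3CCC(C)CC3)CC2)cc1`: > 5000 nM

In an ADME assay on HCT-116 cells (Homo sapiens) for cytotoxicity, read by CellTiter-Glo, with a stated time of 72 h (a lower number here means a stronger inhibitor, a higher number a weaker inhibitor), compound 3 gives > 5000 nM, which is a limit and not a number. Compound 1 gives > 5000 nM, also a limit. Compound 2 gives > 10000 nM, likewise a limit. With no number among the three compounds, compound 3 cannot be ranked against the other two.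

The next compound is compound 4 `CC1CCN(C2CCN(S(=O)(=O)c3cn(C)cn3)CC2)CC1`, and the change from compound 3 is 1-methyl-1H-imidazol-4-yl in place of 4-ethylphenyl on a sulfonyl sulfur. In words, 1-methyl-1H-imidazol-4-yl takes the place of 4-ethylphenyl on a sulfonyl sulfur, whose other neighbour is a sulfonamide nitrogen in a ring.

The closest measured change is a step that the two limits leave unreadable from compound 2 to compound 3. Two others, a step that the two limits leave unreadable from compound 1 to compound 2 and a step that the two limits leave unreadable from compound 1 to compound 3, add no size either. Within the data shown here, no step of readable size or direction is therefore expected in this assay from these data. The expectation rests chiefly on compound 2, which carries 1-methyl-1H-imidazol-2-yl on the sulfonyl sulfur and gives the limit > 10000 nM. The expected step is a step that the limit leaves unreadable from compound 3 to compound 4. Compound 4 is estimated at 10000 nM, with an expected range of 5000 nM to 20000 nM, and a limit rather than a number is the likely report.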

Compound 4, half-maximal inhibitory concentration: > 10000 nM
Compound 4 ended at the assay's limit (the forecaster's own chance of this, stated with the estimate: 90%); the middle value lies on the limit itself.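

In this assay, among these compounds, compound 4, like compound 1, compound 2 and compound 3, is reported only as a limit and not as a number, so no step from any of the other three to compound 4 can be read. The compounds shown leave open whether the groups on the sulfonyl sulfur differ at all in this assay.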